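The source may report more compounds than this note shows. Statements on the series, on what has been measured and on what is new or still open speak of the compounds shown alone.

Compound 3 `Cc1ccc([C@H]2CC(c3cc4ccccc4oc3=O)=NN2c2ccccc2)cc1` is the reference point here. In a functional assay on the whole organism (strain albino) for inhibition, with Rattus norvegicus as the target, read by paw edema, with stated times of 1 h and 2 h, at a dose of 200 mg/kg by the oral route (on this read-out lower numbers stand for less inhibition and higher numbers for more inhibition at the one dose given (going by the name of the read-out)), compound 3 gives 30.1%. Its companions are compound 1 `CN(C)c1ccc([C@H]2CC(c3cc4ccccc4oc3=O)=NN2c2ccccc2)cc1`, which gives 28.4%, and compound 2 `O=c1oc2ccccc2cc1C1=NN(c2ccccc2)[C@@H](c2cccc([N+](=O)[O-])c2)C1`, which gives 26.1%; the steps of a number 1.7 percentage points higher from compound 1 to compound 3 (within the scatter) and a number 4 percentage points higher from compound 2 to compound 3 (within the scatter) both sit inside the scatter, so the three numbers cannot be told apart. Compound 4 `O=c1oc2ccccc2cc1C1=NN(c2ccccc2)[C@@H](c2ccccc2[N+](=O)[O-])C1` is the next step: 2-nitrophenyl in place of 4-methylphenyl on a saturated ring carbon. Among the compounds with values here, the closest precedent is the swap of a nitrophenyl for the methylphenyl, seen as a number 4 percentage points higher from compound 2 to compound 3 (within the scatter), and the related change a number 2.3 percentage points lower from compound 1 to compound 2 (within the scatter); neither moved the read-out beyond the scatter. For compound 4 the expected step is therefore a number 2.6 percentage points lower from compound 3 to compound 4 (within the scatter), essentially no change. The estimate for compound 4 is 27.5%, with a likely range from 20% to 35%.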

Compound 4, a percentage reported as inhibition, in the whole organism at one dose (the size of the read-out at that dose, not a potency): 24.7%
Compound 4: middle estimate off by 2.8 percentage points, on the high side; the measured number falls inside the stated range.
By their numbers in this assay, from the lowest: compounds 4, 2, 1 and 3 (each within the scatter of the next).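

In this assay, putting 2-nitrophenyl on the saturated ring carbon gives a number 5.4 percentage points lower from compound 3 to compound 4 (within the scatter) and a number 3.7 percentage points lower from compound 1 to compound 4 (within the scatter) when it replaces the other groups, so this position has now taken four different substituted phenyl groups without a readable change. Swapping 3-nitrophenyl for 2-nitrophenyl adds something new, a number 1.4 percentage points lower from compound 2 to compound 4 (within the scatter), so the two nitrophenyl groups cannot be told apart here. Nothing measured offers a reason for these numbers. From the compounds shown here alone, whether a carboxylic acid or a plain ethyl chain on this carbon would move the read-out beyond the scatter stays open.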